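This account rests on a few compounds, and the source may have more. Where it says the series, first, only, none or still open, it means among the compounds named here.

The series shares one core, a phenoxyacetyl hydrazide joined to a thiosemicarbazide, and it is read out in an assay on isolated protein for inhibition of A disintegrin and metalloproteinase with thrombospondin motifs 5 (Homo sapiens), read by spectrophotometry, with stated times of 10 min and 3 h; on this read-out higher numbers stand for weaker inhibition and lower numbers for stronger inhibition. Compound 1 `O=C(COc1ccc(Cl)cc1)NNC(=S)NCc1cccc(-c2ccccc2)c1` carries a chlorine on its phenoxy ring and a biphenylmethyl group at the far end; in this assay compound 1 gives 2300 nM. Compound 2 `O=C(COc1ccccc1)NNC(=S)NCCCCC1CCCCC1` keeps the phenoxy ring bare and replaces the biphenylmethyl by a cyclohexylbutyl chain. In this assay compound 2 gives only a limit, > 100000 nM, which is the boundary of the assay and not a number, so compound 2 stands at the limit of > 100000 nM in this assay, at which 1 of the 2 values shown sits, and its true value is known only to lie beyond that boundary. Compound 3 `O=C(COc1ccc([N+](=O)[O-])cc1)NNC(=S)NCCCCC1CCCCC1` is compound 2 with one change: nitro in place of hydrogen on an aromatic carbon. For the measured compounds named here, no measured pair isolates this change, so the expectation rests only on the position of compound 2 at the limit. The step from compound 2 to compound 3 is expected to be an at least 1.4-fold lower number from compound 2 to compound 3 (0.15 log units; that floor lies within the scatter), most likely no gain beyond the scatter, and compound 3 is estimated at 70000 nM, within a range from 10000 nM to 300000 nM.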

Compound 3, half-maximal inhibitory concentration: 810 nM
For compound 3 the middle estimate is 86-fold (1.94 log units) above the measured one; the measured number lies below the stated range.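

In this assay, placing nitro on the aromatic carbon para to a large group, the change phenyl to 4-nitrophenyl, gives an at least 120-fold lower number from compound 2 to compound 3 (2.09 log units; beyond the scatter). The cyclohexylbutyl chain therefore does not rule out a measurable value on this read-out: with that chain kept and the nitro group added, compound 3 gives 810 nM. The true size of the step stays open on one side because the value of compound 2 is a limit and not a number: the limit of > 100000 nM in this assay, at which 1 of the 3 values shown sits.

The compounds shown leave open whether a nitrile, an amine or a carboxylic acid on the same aromatic carbon would lower the number as nitro does, and whether nitro there would also lower it with the biphenylmethyl group of compound 1 at the far end. They also leave open how a shorter or longer chain ending in the cyclohexyl ring would read with the 4-nitrophenyl group kept in place.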